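A Third Aryl Amine on a Core That Shows Nothing Yet

This account rests on a few compounds, and the source may have more. Where it says the series, first, only, none or still open, it means among the compounds named here.

Compound 2 `COc1cccc(Nc2nc(NCc3cccnc3N(C)S(C)(=O)=O)c3c(F)c[nH]c3n2)c1C` reaches only the limit of a functional assay on SMMC-7721 cells (Homo sapiens) for inhibition, read by MTT assay, with a stated time of 48 h; on this read-out lower numbers stand for stronger inhibition and higher numbers for weaker inhibition: compound 2 gives > 100000 nM, a limit rather than a number. Compound 1 `CN(c1ncccc1CNc1nc(Nc2ccc(F)c(Cl)c2)nc2[nH]cc(F)c12)S(C)(=O)=O` likewise gives > 100000 nM in this assay, again a limit. The step that the two limits leave unreadable from compound 1 to compound 2 therefore cannot be read, and the limit of > 100000 nM in this assay, at which 2 of the 2 values shown sit, is all the evidence there is. Compound 3 `CC(=O)NCc1cccc(Nc2nc(NCc3cccnc3N(C)S(C)(=O)=O)c3c(F)c[nH]c3n2)c1` differs from compound 2 by 3-(acetamidomethyl)phenyl in place of 3-methoxy-2-methylphenyl on a nitrogen on an aromatic ring. Among the measured compounds shown here, no measured step gives a direction for this change, so no shift beyond the scatter is expected. The estimated step is a number no higher from compound 2 to compound 3 (the limit leaves the size open). Compound 3 is expected to give 100000 nM, between 30000 nM and 300000 nM, most probably again as a limit.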

Compound 3, half-maximal inhibitory concentration: 21700 nM
Beside the measured number, compound 3's estimate is 4.6-fold (0.66 log units) above it, and the stated range ends above it.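

On a nitrogen on an aromatic ring, the choice of aryl group can move the number in this assay, which the two earlier compounds could not show. Placing 3-(acetamidomethyl)phenyl there gives an at least 4.6-fold lower number from compound 2 to compound 3 (0.66 log units; beyond the scatter), and it gives an at least 4.6-fold lower number from compound 1 to compound 3 (0.66 log units; beyond the scatter). The entering group is larger and carries an amide hydrogen that 3-methoxy-2-methylphenyl lacks, but these compounds cannot say which difference matters.

The step between compound 1 and compound 2 still cannot be read. On these data alone, it also remains open whether a primary amine or a carboxylic acid in place of the acetamide would keep, strengthen or lose this inhibition.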